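This account rests on a few compounds, and the source may have more. Where it says the series, first, only, none or still open, it means among the compounds named here.

Of the compounds shown here, two sharing one core have been tested in an in vitro functional assay on HEK293-A cells for agonist activity at metabotropic glutamate receptor 5 (Rattus norvegicus), read by ELISA; on this read-out higher numbers stand for weaker inhibition and lower numbers for stronger inhibition. Compound 1 `N#Cc1cccc(C#Cc2cccc(C#N)n2)c1` carries two nitrile groups, and in this assay compound 1 gives 20 nM. Compound 2 `CCc1cccc(C#Cc2cccc(C#N)c2)n1` has one of those nitriles exchanged for an ethyl group, and in this assay compound 2 gives 80 nM. That single exchange produced a 4.0-fold higher number from compound 1 to compound 2 (0.60 log units; beyond the scatter). Within the data shown here, compound 2 therefore stands at the higher of the two numbers seen so far, with compound 1 as its only neighbour.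

Compound 3 `CCCCc1cccc(C#Cc2cccc(C#N)c2)n1` differs from compound 2 by ethyl in place of hydrogen on a saturated chain carbon, two bonds along the chain from an aromatic carbon, so the ethyl chain becomes a butyl chain. Among the measured compounds shown here, no measured step is of this kind: the only step known, from compound 1 to compound 2, swapped a nitrile for an ethyl group on an aromatic carbon, and it says nothing direct about lengthening a chain that is already present. Compound 3 is therefore expected to land close to compound 2, with the step of a 1.4-fold higher number from compound 2 to compound 3 (0.14 log units; within the scatter) judged most likely to stay within the usual scatter or only modestly above it. The estimate for compound 3 in this assay is 110 nM, with a plausible range from 30 nM to 400 nM.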

Compound 3, half-maximal inhibitory concentration: 700 nM
Beside the measured number, compound 3's estimate is 6.4-fold (0.80 log units) below it; measured number above the stated range.
By their numbers in this assay, from the lowest: compound 1; then compound 2; then compound 3.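

Among these compounds, the alkyl chain on this aromatic carbon does not tolerate lengthening without cost: going from ethyl to butyl gives an 8.8-fold higher number from compound 2 to compound 3 (0.94 log units; beyond the scatter) in this assay and so means clearly weaker inhibition, whereas the earlier compounds showed only what happens when a nitrile is exchanged for ethyl. Read against the nitrile directly, the butyl group gives a 35-fold higher number from compound 1 to compound 3 (1.54 log units; beyond the scatter) and this large step shows that the two changes run the same way, with the number rising from nitrile to ethyl to butyl and none of these three compounds going against that order. Nothing available explains why the longer chain weakens inhibition.

Three groups cannot show whether the number climbs smoothly with chain length or jumps at one particular length, so a propyl chain, which would fall between ethyl and butyl, and a methyl group, shorter than both, would be the informative comparisons. Also open, going by these compounds, is whether a hexyl chain weakens inhibition further, and whether a branched isopropyl group, a cyclopropyl ring or a methoxy group in the same place would behave like ethyl or like butyl.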